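This account rests on a few compounds, and the source may have more. Where it says the series, first, only, none or still open, it means among the compounds named here.

Compound 2 `COc1cc(C(=O)c2ccc(-c3csc(NC(=O)C(C)(C)N)n3)cc2-n2cncn2)cc(OC)c1OC` holds the lowest number of the two measured in a functional assay on HL-60 cells (Homo sapiens) for antiproliferative activity, read by MTT assay, with a stated time of 72 h; a lower number here means a stronger inhibitor, a higher number a weaker inhibitor; compound 2 gives 5 nM. For the measured compounds named here, its only neighbour, compound 1 `COc1cc(C(=O)c2ccc(-c3csc(NC(=O)[C@@H](N)C(C)C)n3)cc2-n2cncn2)cc(OC)c1OC`, gives 110 nM in this assay, and the step of a 22-fold lower number from compound 1 to compound 2 (1.34 log units; beyond the scatter) is the one that bears on compound 3 `COc1cc(C(=O)c2ccc(-c3csc(NC(=O)[C@@H](N)CC(C)C)n3)cc2-n2cncn2)cc(OC)c1OC`, which differs from compound 2 by 1-amino-3-methylbutyl in place of 1-amino-1-methylethyl on a carbonyl carbon. That step, large and beyond the scatter, followed a move from a branched chain to 1-amino-1-methylethyl; compound 3 moves back toward a branched chain, so a step upward in this assay is expected, a 10-fold higher number from compound 2 to compound 3 (1.00 log units; beyond the scatter). Compound 3 is therefore estimated at 50 nM, within 12 nM to 250 nM.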

Compound 3, half-maximal inhibitory concentration: 76 nM
The estimate for compound 3 lay 1.5-fold (0.18 log units) below the measured number; the range from low to high includes it.
By their numbers in this assay, from the lowest: compound 2; then compounds 3 and 1 (each within the scatter of the next).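

In this assay, the step of a 15-fold higher number from compound 2 to compound 3 (1.18 log units; beyond the scatter) shows that a second chain, 1-amino-3-methylbutyl, also gives a much higher number than 1-amino-1-methylethyl on this carbonyl carbon. The step of a 1.4-fold lower number from compound 1 to compound 3 (0.16 log units; within the scatter) lies within the scatter, so isobutyl and isopropyl on the saturated chain carbon are not told apart here. Nothing available explains these steps. The compounds shown leave open whether a 1-aminocyclopropyl group or an aminomethyl group on this carbonyl carbon would match compound 2 in this assay.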